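A few compounds are considered here, and "the series" means these few. Any claim that something is new, unique, unknown or untested is made for them only; others in the source may bear on it.

Measured compounds and their largest responses:

Compound 1, `C/C(C#Cc1ccc(CCC(=O)O)c(F)c1)=C/CO`, gives 105%.
Compound 2, `O=C(O)CCc1ccc(C#CC2CCCC2)cc1`, gives 94%.
Compound 3, `CCCCCCCC#Cc1ccc(CCC(=O)O)cc1`, gives 84%.

All three values come from a functional assay on 1321-N1 cells for agonist activity at Free fatty acid receptor 1 (Homo sapiens), read by calcium flux, with a stated time of 0.4 s; a higher number here means a larger maximal response, a lower number a smaller maximal response. Among the three numbers compound 1 stands highest: the nearest of the others is compound 2, whose number is lower by a gap beyond the usual scatter, and the furthest is compound 3, whose number is lower still, also beyond the scatter. All three share the same core bearing the propanoic acid chain and the alkyne, and differ in what sits on the far end of the triple bond.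

The account now turns to compound 4, `C=C(C)C#Cc1ccc(CCC(=O)O)c(F)c1`, which has not yet been measured in this assay. It is derived from compound 1 by one change: 1-methylethenyl in place of 3-hydroxy-1-methylprop-1-en-1-yl on a triple-bonded carbon. The 3-hydroxy-1-methylprop-1-en-1-yl group is shortened to 1-methylethenyl, and the single donor and acceptor it carried disappear with it. For the measured compounds named here, no pair of measured compounds differs in exactly this way, so no measured step guides the expectation directly; compounds 2 and 3, with other groups on the triple bond, still show substantial responses in this assay.

The change from compound 1 to compound 4 is therefore expected to be small, with a modest drop, a number 10 percentage points lower from compound 1 to compound 4 (within the scatter), that may not exceed the scatter. For compound 4 the estimated largest response is 95%, with a range from 80% to 110%.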

Compound 4, largest response reached (reported as efficacy), in percent of the reference or control that the assay uses: 106%
Compound 4: the middle estimate sits 11 percentage points below what was measured; the range from low to high includes it.
By their numbers in this assay, from the lowest: compounds 3 and 2 (each within the scatter of the next); then compounds 1 and 4 (each within the scatter of the next).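

In this assay, putting 1-methylethenyl in place of 3-hydroxy-1-methylprop-1-en-1-yl on a triple-bonded carbon gives a number 1 percentage points higher from compound 1 to compound 4 (within the scatter), so the two compounds cannot be told apart by their largest response. For the compounds shown here, this is the first direct view of this position: within this pair, the shorter group, with 0 hydrogen-bond donors and 0 hydrogen-bond acceptors, gives a response matching that of the group carrying 1 of each, so neither the hydroxyl nor the extra carbon is required for the full response in this assay. Nothing available here bears on why the two responses match.

Going by these compounds alone, whether an amine, a carboxylic acid or a longer chain ending in a hydroxyl on the same triple-bonded carbon would also leave the response in place remains open, since this single step covers only one replacement on the core of compound 1. Compound 2 and compound 3 differ from compound 4 in more than one place, so they cannot show how the group on the triple bond alone shapes the response, and the maximal response says nothing about the concentration each compound needs to reach it.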